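The source may hold more compounds than are shown below. What is called first, only, known or untested is meant among the compounds shown, and "the series" means these compounds.

In an ADME assay on MRC5 cells (Homo sapiens) for cytotoxicity, read by fluorescence and resazurin assay, with a stated time of 3 days (on this read-out lower numbers stand for stronger inhibition and higher numbers for weaker inhibition), compound 1 `Cc1ccc(Oc2cccc(CN3CCC(n4cc(C)c(=O)[nH]c4=O)CC3)c2)cc1` gives > 64000 nM, which is a limit of the assay and not a number. Compound 2 `Cc1cn(C2CCN(Cc3cccc(Oc4ccc(F)c(F)c4)c3)CC2)c(=O)[nH]c1=O` gives > 64000 nM, also a limit. Among the measured compounds shown here, compound 3 `Cc1cn(C2CCN(Cc3cccc(Oc4cccc(Cl)c4)c3)CC2)c(=O)[nH]c1=O` gives 21000 nM, the only true number so far and the lowest reading. Compound 4 `Cc1cn(C2CCN(Cc3cccc(Oc4ccc(Cl)c(C(F)(F)F)c4)c3)CC2)c(=O)[nH]c1=O` changes one group on compound 3: 4-chloro-3-(trifluoromethyl)phenyl in place of 3-chlorophenyl on an oxygen on an aromatic ring. The entering 4-chloro-3-(trifluoromethyl)phenyl still carries a chlorine. Two measured steps at this place bear on the change: an at least 3.0-fold lower number from compound 1 to compound 3 (0.48 log units; beyond the scatter), and an at least 3.0-fold lower number from compound 2 to compound 3 (0.48 log units; beyond the scatter). Both show that this group can shift the reading, but neither has a fully known size. A small further lowering is therefore expected, as an estimated 1.5-fold lower number from compound 3 to compound 4 (0.18 log units; within the scatter). The expected value for compound 4 is 14000 nM, with an estimated range of 5000 nM to 40000 nM.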

Compound 4, half-maximal inhibitory concentration: 5280 nM
Compound 4: the middle estimate sits 2.7-fold (0.42 log units) above what was measured, and the stated range covers the measured number.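

In this assay, among the compounds shown here, this position now gives a step between two true numbers, where the earlier steps had only a minimum size: a 4.0-fold lower number from compound 3 to compound 4 (0.60 log units; beyond the scatter). The same change, measured against the two compounds without chlorine, gives an at least 12-fold lower number from compound 2 to compound 4 (1.08 log units; beyond the scatter) and an at least 12-fold lower number from compound 1 to compound 4 (1.08 log units; beyond the scatter). These two sizes are only minimums because compound 1 and compound 2 read at a limit and not a number: the limit of > 64000 nM in this assay, at which 2 of the 4 values shown sit.

The compounds shown leave open whether the added trifluoromethyl or the moved chlorine carries the step. They also leave open how a phenyl ring bearing a nitrile or an amine would read.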